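The source may hold more compounds than are shown below. What is called first, only, known or untested is meant among the compounds shown, and "the series" means these compounds.

Working notes on the aminothiophene series, an assay on CHO cells for displacement of a labelled ligand from adenosine receptor A1 (Homo sapiens), read by scintillation counting, with a stated time of 120 min, tested at 10 uM; a higher number here means more inhibition at the concentration tested (going by the name of the read-out), a lower number less inhibition.

Of the compounds shown here, three have numbers so far. Compound 1 `CC(C)N1CCN(Cc2csc(N)c2C(=O)c2ccc(Cl)cc2)CC1` gives 0% in this assay. Compound 2 `Nc1scc(CN2CCN(c3cccc(Cl)c3Cl)CC2)c1C(=O)c1ccc(Cl)cc1` gives 2% in this assay. Compound 3 `Nc1scc(CN2CCN(c3cccc4ccccc34)CC2)c1C(=O)c1ccc(Cl)cc1` gives 1% in this assay. Compound 3 stands second highest of the three numbers, with compound 1 nearest and compound 2 furthest, both within the scatter. The three steps among them, a number 2 percentage points higher from compound 1 to compound 2 (within the scatter), a number 1 percentage points higher from compound 1 to compound 3 (within the scatter) and a number 1 percentage points lower from compound 2 to compound 3 (within the scatter), all lie within the scatter, so no ordering of the three can be read from this assay.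

Compound 4 `Nc1scc(CN2CCN(c3ccccc3F)CC2)c1C(=O)c1ccc(Cl)cc1` is not yet measured. Relative to compound 3 the change is 2-fluorophenyl in place of naphthalen-1-yl on an amine nitrogen in a ring. The measured steps that bear on it are those varying the same position: a number 1 percentage points higher from compound 1 to compound 3 (within the scatter) and a number 1 percentage points lower from compound 2 to compound 3 (within the scatter), with a number 2 percentage points higher from compound 1 to compound 2 (within the scatter) as a further comparison at that position. None of these moved beyond the scatter, so no step beyond the scatter is expected in this assay; the expected step is no change at the digits printed from compound 3 to compound 4 (within the scatter). Compound 4 is therefore estimated at 1%, in the range -8% to 10%.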

Compound 4, a percentage reported as inhibition, at one concentration (the size of the read-out at that concentration, not a potency): 4%
Compound 4: middle estimate off by 3 percentage points, on the low side; low and high end bracket the measured number.
By their numbers in this assay, from the lowest: compounds 1, 3, 2 and 4 (each within the scatter of the next).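

In this assay, the 2-fluorophenyl group on the amine nitrogen in the ring gives a number 3 percentage points higher from compound 3 to compound 4 (within the scatter), a number 2 percentage points higher from compound 2 to compound 4 (within the scatter) and a number 4 percentage points higher from compound 1 to compound 4 (within the scatter). The position has now taken isopropyl, a single aromatic ring with one fluorine, a single aromatic ring with two chlorines and the two-ring naphthalen-1-yl, and going from 10 heavy atoms to 7 in the step from naphthalen-1-yl to 2-fluorophenyl leaves the number within the scatter, as does every other step among these groups. No data are available that explain why these numbers stay so close.

As far as these compounds go, whether a benzyl group, a longer chain ending in a carboxylic acid or a primary amine at this nitrogen would move the number beyond the scatter remains open. These single-concentration numbers also leave open any potency at this receptor and the effect of changes elsewhere on the shared core.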